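This account rests on a few compounds, and the source may have more. Where it says the series, first, only, none or still open, it means among the compounds named here.

In a functional assay on DU-145 cells (Homo sapiens) for cytotoxicity, read by sulforhodamine B assay, with a stated time of 3 days (on this read-out higher numbers stand for an effect only at larger amounts of compound and lower numbers for an effect already at smaller amounts), compound 1 `Cc1coc(-c2ccc3c(c2O)CCCC3(C)C)c1C(=O)O` gives 3 uM and compound 2 `Cc1coc(-c2ccc3c(c2O)CCCC3(C)C)c1CO` gives 22.7 uM. Compound 2 therefore holds the higher of the two numbers and is the less potent of the pair. Compound 3 `COc1c(-c2occ(C)c2CO)ccc2c1CCCC2(C)C` differs from compound 2 in one place: methyl in place of hydrogen on an oxygen on an aromatic ring, so that hydroxy becomes methoxy. Among the compounds with values here, the only measured step, a 7.6-fold higher number from compound 1 to compound 2 (0.88 log units; beyond the scatter), is modest and concerns a different change, hydroxymethyl in place of carboxy on an aromatic carbon. Within the data shown here, no measured step touches this oxygen, and the data give no direction for the change. The expected shift in this assay is therefore none beyond the scatter, with an estimated 1.1-fold lower number from compound 2 to compound 3 (0.05 log units; within the scatter). For compound 3 the estimate is 20 uM, with an expected range from 7 uM to 55 uM.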

Compound 3, concentration for half-maximal effect: 21.7 uM
Compound 3: the middle estimate sits 1.1-fold (0.04 log units) below what was measured; the range from low to high includes it.
By their numbers in this assay, from the lowest: compound 1; then compounds 3 and 2 (each within the scatter of the next).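

With methoxy in place of hydroxy, compound 2 and compound 3 read alike in this assay, with a 1.0-fold lower number from compound 2 to compound 3 (0.02 log units; within the scatter). Within the data shown here, the earlier step concerned only the carboxy and hydroxymethyl groups, so this is the first reading at the oxygen on the aromatic ring: with hydroxymethyl present, the hydrogen on that oxygen can be replaced by methyl without leaving the scatter. No measurement shown here accounts for this result.

The compounds shown leave open whether methyl on this oxygen would be tolerated in the same way with the carboxy group of compound 1 present, where the number is lower. They also leave open how a longer chain such as benzyl on this oxygen, or an amine in place of the hydroxy, would read.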